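Ethoxy in Place of Methyl on the Outer Ring

The source may hold more compounds than are shown below. What is called first, only, known or untested is meant among the compounds shown, and "the series" means these compounds.

Compound 1, `O=C(O)CS(=O)(=O)c1ccc(OCc2cccc(-c3ccccc3F)c2)cc1`: 257 nM
Compound 2, `COc1ccccc1-c1cccc(COc2ccc(S(=O)(=O)CC(=O)O)cc2)c1`: 195 nM
Compound 3, `Cc1ccc(-c2cccc(COc3ccc(S(=O)(=O)CC(=O)O)cc3)c2)c(Cl)c1`: 36.3 nM

Three compounds share one core and differ only in the substituents on the outer ring. In a functional assay on CHO cells for agonist activity at Free fatty acid receptor 1 (Homo sapiens), read by FLIPR and calcium flux (on this read-out lower numbers stand for an effect already at smaller amounts and higher numbers for an effect only at larger amounts of compound), compound 3 gives the lowest of the three numbers, and its lead over both neighbours lies beyond the scatter: a 7.1-fold lower number from compound 1 to compound 3 (0.85 log units; beyond the scatter) and a 5.4-fold lower number from compound 2 to compound 3 (0.73 log units; beyond the scatter). The two compounds behind it are not separated from each other, since a 1.3-fold lower number from compound 1 to compound 2 (0.12 log units; within the scatter) stays within the scatter.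

Compound 4, `CCOc1ccc(-c2cccc(COc3ccc(S(=O)(=O)CC(=O)O)cc3)c2)c(Cl)c1`, takes the step from compound 3 one group further: ethoxy in place of methyl on an aromatic carbon. For the measured compounds named here, no measured step swaps an alkyl for an alkoxy group at this position. Going by the values given here, the only step that brings in an alkoxy group at all, a 1.3-fold lower number from compound 1 to compound 2 (0.12 log units; within the scatter), concerns methoxy in place of fluoro elsewhere on the ring and lies within the scatter, so it gives no direction for the present change. The halogen that marks compound 3 out is kept in compound 4. On that basis the step of a 1.1-fold higher number from compound 3 to compound 4 (0.04 log units; within the scatter) is expected to stay within the scatter. Compound 4 is accordingly estimated at 40 nM, with a range from 15 nM to 120 nM.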

Compound 4, half-maximal effective concentration in the Free fatty acid receptor 1 assay: 51.3 nM
The estimate for compound 4 lay 1.3-fold (0.11 log units) below the measured number; the measured number falls inside the stated range.
By their numbers in the Free fatty acid receptor 1 assay, from the lowest: compounds 3 and 4 (each within the scatter of the next); then compounds 2 and 1 (each within the scatter of the next).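

In the Free fatty acid receptor 1 assay, the position para to a large group and meta to a chloro group accepts ethoxy, with 3 heavy atoms and 1 hydrogen-bond acceptor, in place of methyl, with 1 heavy atom and 0 hydrogen-bond acceptors, and the number stays within the scatter (a 1.4-fold higher number from compound 3 to compound 4 (0.15 log units; within the scatter)). The 2-chloro-4-ethoxyphenyl group also stays clear of the two outer rings without chloro, with both steps beyond the scatter (a 3.8-fold lower number from compound 2 to compound 4 (0.58 log units; beyond the scatter); a 5.0-fold lower number from compound 1 to compound 4 (0.70 log units; beyond the scatter)), so this separation is not confined to the 2-chloro-4-methylphenyl group of compound 3. In a physicochemical assay for lipophilicity, using the shake flask method, in phosphate buffer, measured as octanol-water partition, with a stated time of 24 h, at pH 7.4, tested at 100 uM (on this read-out higher numbers stand for higher lipophilicity and lower numbers for lower lipophilicity), compound 3 gives 3.05 and compound 4 gives 3.12 and the same change also stays within the scatter (a number 0.07 log units higher from compound 3 to compound 4 (within the scatter)), and nothing available accounts for either result.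

The compounds shown leave open whether a longer chain such as butoxy, an amine or a carboxylic acid at this position would keep the number in the same range. They also leave open how the separation divides between the chloro group and the group at this position: the steps from compound 1 and compound 2 change both at once.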